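The source may hold more compounds than are shown below. What is called first, only, known or untested is meant among the compounds shown, and "the series" means these compounds.

Working notes on the series. Compound 1 `O=C(O)c1csc([C@H]2CC[C@@H]3[C@@H](/C=C/[C@@H](O)COc4ccccc4)[C@H](O)C[C@@H]3O2)n1` gives 7.9 nM in a functional assay on CHO cells for agonist activity at prostaglandin E2 receptor EP2 subtype (Homo sapiens), read by HTRF and cAMP accumulation, with a stated time of 30 min; on this read-out lower numbers stand for an effect already at smaller amounts and higher numbers for an effect only at larger amounts of compound. Compound 2 `O=C(O)c1csc([C@H]2CC[C@@H]3[C@@H](COc4ccc(F)cc4)[C@H](O)C[C@@H]3O2)n1` gives 7 nM in this assay, and compound 3 `O=C(O)c1csc([C@H]2CC[C@@H]3[C@@H](COc4cccc(OC(F)(F)F)c4)[C@H](O)C[C@@H]3O2)n1` gives 0.9 nM. Compound 2 therefore stands second highest of the three numbers: its gap to compound 1 lies within the scatter, while its gap to compound 3 lies beyond it, with compound 3 at the smaller number. Compound 4 `O=C(O)c1csc([C@H]2CC[C@@H]3[C@@H](CCCOc4ccccc4)[C@H](O)C[C@@H]3O2)n1` is not yet measured. It differs from compound 2 as follows: 2-phenoxyethyl in place of 4-fluorophenoxy on a saturated chain carbon bound to a saturated ring carbon. Among the compounds with values here, no measured pair shows this change, so nothing fixes its direction. Because compound 1 with its longer side chain sits at 7.9 nM, close to compound 2, no step beyond the scatter is expected in either direction. Compound 4 is estimated at 10 nM, range 3 nM to 40 nM, an expected step of a 1.4-fold higher number from compound 2 to compound 4 (0.15 log units; within the scatter).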

Compound 4, half-maximal effective concentration: 10 nM
For compound 4 middle estimate and measured number coincide at the digits printed; the measured number falls inside the stated range.
By their numbers in this assay, from the lowest: compound 3; then compounds 2, 1 and 4 (each within the scatter of the next).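

In this assay, within the data shown here, 2-phenoxyethyl in place of 4-fluorophenoxy on a saturated chain carbon bound to a saturated ring carbon gives a 1.4-fold higher number from compound 2 to compound 4 (0.15 log units; within the scatter), the first measured single change at this place. This place therefore accepts the longer group without the fluorine and without a step beyond the scatter. No measurement at hand explains this result. Going by these compounds, it remains open whether a still longer chain, or an amine in the chain, would keep the number within the scatter of compound 4.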